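A few compounds are considered here, and "the series" means these few. Any claim that something is new, unique, unknown or untested is made for them only; others in the source may bear on it.

Compound 1 `COCC(=O)N(Cc1ccc(OC)c(O)c1)c1cc(OC)c(OC)c(OC)c1` gives 230 nM in a functional assay on HCT-116 cells (Homo sapiens) for inhibition, read by MTT assay, with a stated time of 48 h; on this read-out higher numbers stand for weaker inhibition and lower numbers for stronger inhibition.
Compound 2 `COc1ccc(CN(C(C)=O)c2cc(OC)c(OC)c(OC)c2)cc1O` gives 270 nM in this assay.
Compound 3 `COc1ccc(CN(C(=O)C=C(C)C)c2cc(OC)c(OC)c(OC)c2)cc1O` gives 290 nM in this assay.

Compound 3 carries the highest of the three numbers, but both gaps are within the scatter: a 1.3-fold higher number from compound 1 to compound 3 (0.10 log units; within the scatter) and a 1.1-fold higher number from compound 2 to compound 3 (0.03 log units; within the scatter). Compound 4 `C=C(C)C(=O)N(Cc1ccc(OC)c(O)c1)c1cc(OC)c(OC)c(OC)c1` differs from compound 3 by 1-methylethenyl in place of 2-methylprop-1-en-1-yl on a carbonyl carbon. The three measured steps all concern the group on this same carbonyl carbon and none left the scatter: a 1.2-fold higher number from compound 1 to compound 2 (0.07 log units; within the scatter) alongside the two steps above. On that basis no step beyond the scatter is expected in this assay for the change from compound 3 to compound 4, in either direction. Compound 4 is therefore estimated at 280 nM, with an expected range from 140 nM to 560 nM. The step this estimate implies is a 1.0-fold lower number from compound 3 to compound 4 (0.02 log units; within the scatter).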

Compound 4, half-maximal inhibitory concentration: 200 nM
Beside the measured number, compound 4's estimate is 1.4-fold (0.15 log units) above it; the range from low to high includes it.
By their numbers in this assay, from the lowest: compounds 4, 1, 2 and 3 (each within the scatter of the next).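

With 1-methylethenyl on the carbonyl carbon, a fourth group has now been read at this position in this assay, and the new steps are a 1.5-fold lower number from compound 3 to compound 4 (0.16 log units; within the scatter) and a 1.4-fold lower number from compound 2 to compound 4 (0.13 log units; within the scatter) and a 1.2-fold lower number from compound 1 to compound 4 (0.06 log units; within the scatter). Methyl, methoxymethyl, 2-methylprop-1-en-1-yl and 1-methylethenyl are therefore not told apart by this read-out. No data at hand offer an explanation for this flat response.

From the compounds shown here alone, whether an amine, a carboxylic acid or a longer chain on this carbonyl carbon would give a step beyond the scatter remains open. Going by these compounds, the core is the same in all four compounds, so the effect of changing it also remains open.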